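A Smaller Ether Ring on the Amide Nitrogen

A few compounds are considered here, and "the series" means these few. Any claim that something is new, unique, unknown or untested is made for them only; others in the source may bear on it.

Three compounds share one core and differ only in the group on the carbonyl carbon. Compound 1 `CCN(CC)S(=O)(=O)c1ccc(S(=O)(=O)N2CCC[C@@H](C(=O)N3CCC(O)CC3)C2)cc1` carries 4-hydroxypiperidin-1-yl there; in a functional assay on MIA PaCa-2 cells (Homo sapiens) for inhibition, read by MTT assay, with a stated time of 3 days (on this read-out higher numbers stand for weaker inhibition and lower numbers for stronger inhibition), compound 1 gives > 10000 nM, which is a limit of the assay and not a number. Compound 2 `CCN(CC)S(=O)(=O)c1ccc(S(=O)(=O)N2CCC[C@@H](C(=O)N3CCOCC3)C2)cc1` carries morpholin-4-yl; in this assay compound 2 gives > 10000 nM, again a limit. Compound 3 `CCN(CC)S(=O)(=O)c1ccc(S(=O)(=O)N2CCC[C@@H](C(=O)NC3CCOCC3)C2)cc1` carries (oxan-4-yl)amino; in this assay compound 3 gives > 10000 nM, also a limit. The steps among them, a step that the two limits leave unreadable from compound 1 to compound 2, a step that the two limits leave unreadable from compound 1 to compound 3 and a step that the two limits leave unreadable from compound 2 to compound 3, cannot be read, since all three values sit at the limit of > 10000 nM in this assay, at which 3 of the 3 values shown sit. Compound 3 therefore stands only at a limit, with no number of its own.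

Compound 4 `CCN(CC)S(=O)(=O)c1ccc(S(=O)(=O)N2CCC[C@@H](C(=O)N[C@H]3CCOC3)C2)cc1` differs from compound 3 by oxolan-3-yl in place of oxan-4-yl on an amide-type nitrogen. For the measured compounds named here, no measured step touches this change, and the three steps that exist are unreadable, so there is no basis for expecting a readable step in this assay in either direction. The step that the estimate below implies, a step that the limit leaves unreadable from compound 3 to compound 4, is an expectation only. For compound 4 the estimate in this assay is 15000 nM, with a range from 5000 nM to 50000 nM, most likely reported once more as a limit.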

Compound 4, half-maximal inhibitory concentration: > 10000 nM
Compound 4 ended at the assay's limit; the forecaster's own chance of this, stated with the estimate: 85%; the middle value lies beyond the limit too.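

No step between compound 4 and compound 1, compound 2 or compound 3 can be read, because all four compounds stand at the same limit of this assay and none has a number of its own: the limit of > 10000 nM in this assay, at which 4 of the 4 values shown sit.

The compounds shown leave open whether oxolan-3-yl in place of oxan-4-yl on the amide-type nitrogen changes inhibition at all, and how the four groups on the carbonyl carbon would rank.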